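The source may hold more compounds than are shown below. What is called first, only, known or untested is meant among the compounds shown, and "the series" means these compounds.

Compound 1 `CCc1nnc(-c2ccc(-c3ccccc3)cc2)n1-c1ccccc1C` is the reference point of this small set. In an assay on C6 glioma cells for displacement of a labelled ligand from sodium- and chloride-dependent glycine transporter 1 (Rattus norvegicus), read by scintillation counting, with stated times of 30 min and 10 min (a lower number here means a stronger inhibitor, a higher number a weaker inhibitor), compound 1 gives 300 nM, the lowest number among the three measured compounds. Compound 2 `CCc1nnc(-c2ccc(-c3ccccc3)cc2)n1-c1cccc(COC)c1C` carries a methoxymethyl in place of hydrogen on an aromatic carbon and gives 2400 nM; compound 3 `CCc1nnc(-c2ccc(-c3ccccc3)cc2)n1-c1cccc(Br)c1C` carries bromo in place of hydrogen on the same aromatic carbon and gives 2200 nM. Both substitutions move the number the same way: an 8.0-fold higher number from compound 1 to compound 2 (0.90 log units; beyond the scatter) and a 7.3-fold higher number from compound 1 to compound 3 (0.87 log units; beyond the scatter), while between the two substituted compounds a 1.1-fold lower number from compound 2 to compound 3 (0.04 log units; within the scatter).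

Compound 4 `CCc1nnc(-c2ccc(-c3ccccc3)cc2)n1-c1cccc(C(N)=O)c1C` is not yet measured in this assay. It differs from compound 1 in one place: carbamoyl in place of hydrogen on an aromatic carbon. The entering group occupies the aromatic carbon that holds the methoxymethyl of compound 2 and the bromo of compound 3. Both measured steps from compound 1, an 8.0-fold higher number from compound 1 to compound 2 (0.90 log units; beyond the scatter) and a 7.3-fold higher number from compound 1 to compound 3 (0.87 log units; beyond the scatter), therefore bear on the new step; they are of modest and nearly equal size in the same direction, although the two groups that entered there are quite unlike one another. The expectation for compound 4 is accordingly a higher number than for compound 1, of comparable size: a 7.3-fold higher number from compound 1 to compound 4 (0.87 log units; beyond the scatter). Compound 4 is estimated at 2200 nM, with a range from 700 nM to 7000 nM.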

Compound 4, half-maximal inhibitory concentration: 3900 nM
Estimate against measurement, compound 4: 1.8-fold (0.25 log units) below; measured number inside the range.
By their numbers in this assay, from the lowest: compound 1; then compounds 3, 2 and 4 (each within the scatter of the next).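

Carbamoyl on this aromatic carbon in this assay gives a 13-fold higher number from compound 1 to compound 4 (1.11 log units; beyond the scatter), so a third entering group, this one with a hydrogen-bond donor, also raises the number relative to hydrogen at this position. The steps among the substituted compounds, a 1.8-fold higher number from compound 3 to compound 4 (0.25 log units; within the scatter) and a 1.6-fold higher number from compound 2 to compound 4 (0.21 log units; within the scatter), stay within the scatter, so bromo, methoxymethyl and carbamoyl all sit on the same side of hydrogen here and the data give no ranking among them. Nothing at hand accounts for the change from hydrogen or for the lack of separation among the three groups.

Open, as far as these compounds go, is whether any group on this carbon can keep the number of compound 1 at 300 nM; fluoro, a hydroxyl, an amine or a carboxylic acid would extend the range of groups tested at this position. Also open, from the compounds shown here alone, is whether the amide hydrogen plays any part in the number for compound 4, a question that a nitrile or a dimethylamide in place of the carbamoyl would begin to address.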